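Ring closure on the amide nitrogen: compound 3

The source may hold more compounds than are shown below. What is called first, only, known or untested is meant among the compounds shown, and "the series" means these compounds.

Compound 2 `CCC(COC)N(CC(=O)Nc1cc(F)cc(F)c1)C(=O)c1ccc(-c2ccccn2)cc1` gives 1260 nM in an assay on HEK293 cells for inhibition of sodium- and chloride-dependent glycine transporter 1 (Homo sapiens), read by scintillation proximity assay (on this read-out higher numbers stand for weaker inhibition and lower numbers for stronger inhibition), the higher of the two numbers seen so far, with compound 1 `O=C(CN(C(=O)c1ccc(-c2ccccn2)cc1)C1CCCCC1)Nc1cc(F)cc(F)c1` giving 63.1 nM. For the measured compounds named here, the one measured step, a 20-fold higher number from compound 1 to compound 2 (1.30 log units; beyond the scatter), falls on the same amide-type nitrogen as the change now in view. Compound 3 `O=C(CN(C(=O)c1ccc(-c2ccccn2)cc1)C1CCOC1)Nc1cc(F)cc(F)c1` carries oxolan-3-yl in place of 1-(methoxymethyl)propyl on an amide-type nitrogen. Going by the values given here, only the step from compound 1 to compound 2 bears on this; it was large, and with a ring coming back on that nitrogen, part of it is expected to reverse in this assay, downward. Compound 3 is expected at 300 nM (range 100 nM to 1000 nM), an expected 4.2-fold lower number from compound 2 to compound 3 (0.62 log units; beyond the scatter).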

Compound 3, half-maximal inhibitory concentration in the sodium- and chloride-dependent glycine transporter 1 assay: 1260 nM
Estimate against measurement, compound 3: 4.2-fold (0.62 log units) below; measured number outside the range, above it.
By their numbers in the sodium- and chloride-dependent glycine transporter 1 assay, from the lowest: compound 1; then compounds 2 and 3 (each within the scatter of the next).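

In the sodium- and chloride-dependent glycine transporter 1 assay there is no change at the digits printed from compound 2 to compound 3 (within the scatter) despite the ring now on the amide-type nitrogen, so a ring alone does not restore the number of compound 1. In the sodium- and chloride-dependent glycine transporter 1 assay there also remains a 20-fold higher number from compound 1 to compound 3 (1.30 log units; beyond the scatter) with oxolan-3-yl in place of cyclohexyl. In a physicochemical assay for lipophilicity (on this read-out higher numbers stand for higher lipophilicity and lower numbers for lower lipophilicity), compound 2 gives 3.3 and compound 3 gives 2.5. The same exchange that leaves inhibition level does lower lipophilicity: the measured distribution coefficient of compound 2, 3.3, and of compound 3, 2.5, a number 0.80 log units lower (beyond the scatter)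

Still open, from the compounds shown here alone, is whether the gap to cyclohexyl follows from ring size or from the ring oxygen. Cyclopentyl and oxan-4-yl on that nitrogen would separate the two.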